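A few compounds are considered here, and "the series" means these few. Any claim that something is new, unique, unknown or untested is made for them only; others in the source may bear on it.

Measured in a functional assay on HL-60 cells (Homo sapiens) for cytotoxicity, read by MTT assay, with a stated time of 4 days; a lower number here means a stronger inhibitor, a higher number a weaker inhibitor:
- compound 1 `C=C1C[C@]23C[C@@]1(O)CC[C@@H]2c1cccc(C)c1[C@@H]3Cn1cc(-c2ccc(C)cc2)nn1`: > 20000 nM, a limit of the assay rather than a number.
- compound 2 `C=C1C[C@]23C[C@@]1(O)CC[C@H]2c1ccc(O)c(C)c1[C@@H]3Cn1cc(-c2ccc(OC)cc2)nn1`: > 20000 nM, again a limit of the assay.
- compound 3 `C=C1C[C@]23C[C@@]1(O)CC[C@H]2c1cc(Br)c(O)c(C)c1[C@@H]3Cn1cc(-c2ccc(Cl)cc2)nn1`: 5590 nM.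

Among the compounds with values here, compound 1 stands at the limit of > 20000 nM in this assay, at which 2 of the 3 values shown sit, so its position on the scale is only bounded from one side; no ordering between compound 1 and compound 2 can be read from the numbers, and compound 3 is the only member of the set with a finite value in this assay.

Compound 4 `C=C1C[C@]23C[C@@]1(O)CC[C@@H]2c1cccc(C)c1[C@@H]3Cn1cc(-c2ccc(F)cc2)nn1` differs from compound 1 by fluoro in place of methyl on an aromatic carbon. Within the data shown here, no measured pair in the set shows this change, so the size of its effect in this assay is unknown. Given that compound 1 sits at the limit, compound 4 is expected to remain at or near the limit as well, with the step of a number no higher from compound 1 to compound 4 (the limit leaves the size open) taken as no change beyond the scatter. The estimate for compound 4 is 20000 nM, in the range 6000 nM to 60000 nM.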

Compound 4, half-maximal inhibitory concentration: > 20000 nM
Compound 4 ended at the assay's limit; the forecaster's own chance of this, stated with the estimate: 70%; the middle value sits exactly at the limit.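

Compound 1 and compound 4 give no readable step in this assay, as each value is a limit and not a number: the limit of > 20000 nM in this assay, at which 3 of the 4 values shown sit.

The compounds shown leave open whether 4-fluorophenyl in place of 4-methylphenyl changes potency at all on the shared core.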